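A few compounds are considered here, and "the series" means these few. Any claim that something is new, unique, unknown or untested is made for them only; others in the source may bear on it.

Compound 1 `O=C(N/N=C/c1cccc(Br)c1)Nc1cc2c(Nc3ccc(F)c(Cl)c3)ncnc2cc1O[C@H]1CCOC1`: 32300 nM
Compound 2 `O=C(N/N=C/c1cc(Br)c(O)c(Br)c1)Nc1cc2c(Nc3ccc(F)c(Cl)c3)ncnc2cc1O[C@H]1CCOC1`: 2740 nM

For the measured compounds named here, in a functional assay on HepG2 cells (Homo sapiens) for cytotoxicity, read by MTT assay, with a stated time of 72 h (a higher number here means a weaker inhibitor, a lower number a stronger inhibitor), compound 1 gives 32300 nM, the higher of the two numbers measured so far. Compound 3 `COc1cc2ncnc(Nc3ccc(F)c(Cl)c3)c2cc1NC(=O)N/N=C/c1cccc(Br)c1` differs from compound 1 in one group, with methyl in place of oxolan-3-yl on an oxygen on an aromatic ring. Going by the values given here, the only measured step, a 12-fold lower number from compound 1 to compound 2 (1.07 log units; beyond the scatter), is large, but it concerns a different place, a carbon with a double bond to nitrogen, so no measured step tests this change. In this assay the expected step, a 1.2-fold lower number from compound 1 to compound 3 (0.06 log units; within the scatter), is therefore estimated to stay within the scatter, with no clear direction. For compound 3 the expected value is 28000 nM, with an estimated range of 9000 nM to 80000 nM.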

Compound 3, half-maximal inhibitory concentration: "not active" (no number reported)
For compound 3 the study gives words and no number, and the estimate cannot be compared.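

For the compounds shown here, compound 3 is reported in this assay only as "not active", without a number, so no step from compound 1 to compound 3 can be read. How much methyl in place of oxolan-3-yl changes the number stays open, and no evidence available here explains the result.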